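Swapping hydroxyphenyl for chlorophenyl in a thiosemicarbazone series

The source may hold more compounds than are shown below. What is called first, only, known or untested is meant among the compounds shown, and "the series" means these compounds.

Compound 1 `CC1=CC[C@H](C(C)(C)N=C=S)CC1`: "not determined" (no result reported)
Compound 2 `CC1=CC[C@H](C(C)(C)NC(=S)N/N=C/c2ccc(O)cc2)CC1`: > 100000 nM
Compound 3 `CC1=CC[C@H](C(C)(C)NC(=S)N/N=C/c2ccc(N(C)C)cc2)CC1`: > 100000 nM

In a functional assay on UACC-62 cells (Homo sapiens) for inhibition, read by sulforhodamine B assay, with a stated time of 48 h (a higher number here means a weaker inhibitor of growth, a lower number a stronger inhibitor of growth), compound 2 reaches only a limit, > 100000 nM, so its standing among the measured compounds cannot be fixed. Compound 3 likewise sits at a limit, > 100000 nM. Compound 1 carries no result. Going by the values given here, the one measured step, a step that the two limits leave unreadable from compound 2 to compound 3, stays unreadable, owing to the limit of > 100000 nM in this assay, at which 2 of the 3 values shown sit. Compound 4 `CC1=CC[C@H](C(C)(C)NC(=S)N/N=C/c2cccc(Cl)c2)CC1` differs from compound 2 by 3-chlorophenyl in place of 4-hydroxyphenyl on a carbon with a double bond to nitrogen. Among the compounds with values here, no measured step gives a readable size for this change; with both measured neighbours at the limit, compound 4 is expected to stay at or near it, a step of a number no higher from compound 2 to compound 4 (the limit leaves the size open) estimated as no readable change. Compound 4 is therefore estimated at 100000 nM, within 30000 nM to 300000 nM.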

Compound 4, concentration for total growth inhibition: 39800 nM
Beside the measured number, compound 4's estimate is 2.5-fold (0.40 log units) above it; the measured number falls inside the stated range.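

In this assay, going by these compounds alone, placing 3-chlorophenyl in place of 4-hydroxyphenyl gives an at least 2.5-fold lower number from compound 2 to compound 4 (0.40 log units; beyond the scatter), the only readable step so far, so a change at this position can move the growth read-out. The true size of the step stays unknown because compound 2 has only a limit: the limit of > 100000 nM in this assay, at which 2 of the 4 values shown sit.

Since 3-chlorophenyl and 4-hydroxyphenyl differ both in the group and in its place on the ring, compound 2 and compound 4 cannot separate these two changes. On these data alone, how a ring carrying a bromine or a nitrile would read remains open.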